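Thioether chain variation on the shared core

The source may report more compounds than this note shows. Statements on the series, on what has been measured and on what is new or still open speak of the compounds shown alone.

Measured so far:
compound 1 `Cc1cc(Nc2cc(-c3ccccc3)[nH]n2)n2nc(SCCCc3ccccc3)nc2n1` 6510 nM
compound 2 `Cc1cc(Nc2cc(-c3ccccc3)[nH]n2)n2nc(SCc3cccc(Br)c3)nc2n1` 4820 nM
compound 3 `Cc1cc(Nc2cc(-c3ccccc3)[nH]n2)n2nc(SCCc3ccccc3)nc2n1` 5620 nM

In a functional assay on MGC-803 cells (Homo sapiens) for inhibition, read by MTT assay, with a stated time of 72 h (a higher number here means a weaker inhibitor, a lower number a stronger inhibitor), compound 1 gives 6510 nM, the largest of the three numbers, yet the steps of a 1.2-fold lower number from compound 1 to compound 3 (0.06 log units; within the scatter) and a 1.4-fold lower number from compound 1 to compound 2 (0.13 log units; within the scatter) both sit within the scatter, so the three compounds cannot be ranked. Compound 4 `Cc1cc(Nc2cc(-c3ccccc3)[nH]n2)n2nc(SCc3ccc(C(F)(F)F)cc3)nc2n1` is unmeasured; the change from compound 1 is 4-(trifluoromethyl)phenyl in place of phenethyl on a saturated chain carbon bound to a sulfur. For the measured compounds named here, the nearest precedent is a 1.4-fold lower number from compound 1 to compound 2 (0.13 log units; within the scatter), which also swaps the phenethyl for an aryl ring on the chain carbon bound to sulfur, and a 1.2-fold higher number from compound 2 to compound 3 (0.07 log units; within the scatter) shows the reverse type of change, both inside the scatter. No step beyond the scatter is therefore expected in this assay. For compound 4 the expected step is a 1.3-fold lower number from compound 1 to compound 4 (0.11 log units; within the scatter), giving an estimated 5000 nM with a range of 2500 nM to 10000 nM.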

Compound 4, half-maximal inhibitory concentration: 3520 nM
Beside the measured number, compound 4's estimate is 1.4-fold (0.15 log units) above it; measured number inside the range.
By their numbers in this assay, from the lowest: compounds 4, 2, 3 and 1 (each within the scatter of the next).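

In this assay, for the compounds shown here, compound 4 is the only compound here carrying fluorine, and its steps are a 1.8-fold lower number from compound 1 to compound 4 (0.27 log units; within the scatter) and a 1.6-fold lower number from compound 3 to compound 4 (0.20 log units; within the scatter) and a 1.4-fold lower number from compound 2 to compound 4 (0.14 log units; within the scatter) with none leaving the scatter. The saturated chain carbon bound to a sulfur thus accepts 4-(trifluoromethyl)phenyl, with 10 heavy atoms against 8 for phenethyl, and the four compounds still cannot be ranked. No supporting data bear on these numbers. From the compounds shown here alone, whether an amine or a carboxylic acid on the ring, or a chain longer than 3-phenylpropyl, would give a step beyond the scatter stays open.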